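From a Dimethoxybenzyl to a tert-Butoxycarbonyl on the Ring Nitrogen

This account rests on a few compounds, and the source may have more. Where it says the series, first, only, none or still open, it means among the compounds named here.

Two analogues of one shared core have been examined in an ADME assay on MRC5 cells (Homo sapiens) for cytotoxicity; on this read-out higher numbers stand for weaker inhibition and lower numbers for stronger inhibition. For compound 1 `CCOC(=O)COc1cc(-c2cc(=O)c3c(O)cc(OCC(=O)N4CCN(Cc5ccc(OC)c(OC)c5OC)CC4)cc3o2)ccc1OC` the read-out is a limit of the assay, > 70000 nM. Among the compounds with values here, compound 2 `CCOC(=O)COc1cc(-c2cc(=O)c3c(O)cc(OCC(=O)N4CCN(Cc5ccc(OC)cc5OC)CC4)cc3o2)ccc1OC` gives 5600 nM in this assay, and among the two values it holds the only actual number. Within the data shown here, the single measured step, an at least 12-fold lower number from compound 1 to compound 2 (1.09 log units; beyond the scatter), is a hydrogen in place of methoxy on an aromatic carbon, and its starting point rests on (the limit of > 70000 nM in this assay, at which 1 of the 2 values shown sits).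

Compound 3 `CCOC(=O)COc1cc(-c2cc(=O)c3c(O)cc(OCC(=O)N4CCN(C(=O)OC(C)(C)C)CC4)cc3o2)ccc1OC` differs from compound 2 by tert-butoxycarbonyl in place of 2,4-dimethoxybenzyl on an amine nitrogen in a ring. Among the measured compounds shown here, the measured step concerns one methoxy on the benzyl group, not an exchange of the whole group for a carbamate, so no measured step bears directly on this change. Compound 3 is therefore estimated at 20000 nM, with a range from 4000 nM to 70000 nM. The expected step, a 3.6-fold higher number from compound 2 to compound 3 (0.55 log units; beyond the scatter), is an estimate without a measured precedent.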

Compound 3, half-maximal inhibitory concentration: 3800 nM
The estimate for compound 3 lay 5.3-fold (0.72 log units) above the measured number; the whole stated range lies above it.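

In this assay, replacing the whole 2,4-dimethoxybenzyl with tert-butoxycarbonyl on the ring nitrogen gives a 1.5-fold lower number from compound 2 to compound 3 (0.17 log units; within the scatter), so this pair cannot be told apart. The read-out at this position therefore does not depend on the six-membered aromatic ring of the benzyl group, since a group with no ring serves compound 3 equally well within the scatter. A single methoxy on the benzyl group, by contrast, accounts for an at least 12-fold lower number from compound 1 to compound 2 (1.09 log units; beyond the scatter), a step that starts from a limit of the assay, so the sensitivity lies in that substitution and not in the presence of the benzyl group as such.

As far as these compounds go, what the read-out would be with only hydrogen on the ring nitrogen, or with an unsubstituted benzyl, remains open. So does the effect of a carboxylic acid in place of the ethyl ester.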